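The compounds below may be only part of what the source reports. "The series", "measured", "known", "first", "only" and "open" are said of these compounds alone.

Of the compounds shown here, three from this study have been measured in an ADME assay on HepG2 2.2.15 cells (Homo sapiens) for cytotoxicity; a lower number here means a stronger inhibitor, a higher number a weaker inhibitor. Compound 1, `O=C1CCCC2=C1C(c1ccc(F)cc1Cl)N=C(c1cnccn1)N2`, gives 777000 nM in this assay. Compound 2, `O=C1CCCC2=C1C(c1ccccc1Cl)N=C(c1cnccn1)N2`, gives 1470000 nM in this assay. Compound 3, `CC1(C)CC(=O)C2=C(C1)NC(c1cccnc1)=NC2c1ccc(F)cc1`, gives 145000 nM in this assay, the lowest of the three numbers and beyond the scatter from both others.

Compounds 1 and 2 differ in one place: hydrogen in place of fluoro on an aromatic carbon. The step that goes with it is a 1.9-fold higher number from compound 1 to compound 2 (0.28 log units; within the scatter), so the two numbers cannot be told apart with confidence.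

Compound 4, `CC1(C)CC(=O)C2=C(C1)NC(c1cccnc1)=NC2c1ccccc1`, has not yet been measured. It differs from compound 3 in one place: hydrogen in place of fluoro on an aromatic carbon. Going by the values given here, this is the same kind of change as the one from compound 1 to compound 2, though not the same: in the earlier pair the place is also meta to a chloro group, while in compound 3 the ring carries no such group. The cores of compounds 1 and 3 also differ, and that difference is not broken down here.

Among the compounds with values here, the only direct guide is the step from compound 1 to compound 2, which stayed within the scatter. On that basis the step from compound 3 to compound 4 is expected to be a 1.7-fold higher number from compound 3 to compound 4 (0.22 log units; within the scatter), a small rise that rests on a 1.9-fold higher number from compound 1 to compound 2 (0.28 log units; within the scatter). Compound 4 is therefore estimated at 240000 nM, with a likely range from 100000 nM to 600000 nM.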

Compound 4, half-maximal inhibitory concentration: 173000 nM
Beside the measured number, compound 4's estimate is 1.4-fold (0.14 log units) above it; measured number inside the range.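

Going from 4-fluorophenyl to phenyl on the core of compound 3 gives, in this assay, a 1.2-fold higher number from compound 3 to compound 4 (0.08 log units; within the scatter), so the two numbers cannot be told apart with confidence. Set beside the earlier pair, the same swap of fluoro for hydrogen gives steps on the two cores that cannot be distinguished from each other: the same change on two cores in this assay, a 1.9-fold higher number (0.28 log units; within the scatter) from compound 1 to compound 2 and a 1.2-fold higher number (0.08 log units; within the scatter) from compound 3 to compound 4, 1.6-fold (0.20 log units) apart, within the scatter of two such steps This shows that, in these two pairs, the change leaves no readable mark on the number and that the small step seen on one core carried over to the other, but it does not show that the change has no effect at all, as a small real effect could still lie hidden in the scatter, and two pairs are too few to make a rule for the whole series.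

The compounds shown compare only fluoro with hydrogen, which leaves open whether a different group at that place, such as a methoxy group, an amine or a carboxylic acid, would produce a step beyond the scatter. The two cores also differ in more than one place, and no pair shown separates those differences, so what each contributes to the number remains open.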